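Replacing Dimethoxyphenyl with a Halogenated Ring

This account rests on a few compounds, and the source may have more. Where it says the series, first, only, none or still open, it means among the compounds named here.

Measured in a functional assay on HCT-116 cells (Homo sapiens) for antiproliferative activity, read by MTT assay; on this read-out lower numbers stand for stronger inhibition and higher numbers for weaker inhibition:
- compound 1 `Cn1c(=O)c(=O)n(C2CCCC2)c2nc(N/N=C/c3ccc(F)c(Cl)c3)ncc21` gives 9020 nM
- compound 2 `Cn1c(=O)c(=O)n(C2CCCC2)c2nc(N/N=C/c3ccco3)ncc21` gives 78700 nM
- compound 3 `COc1ccc(/C=N/Nc2ncc3c(n2)n(C2CCCC2)c(=O)c(=O)n3C)c(OC)c1` gives > 100000 nM, which is a limit

Compound 3 has no number, only (the limit of > 100000 nM in this assay, at which 1 of the 3 values shown sits).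

Compound 4 `Cn1c(=O)c(=O)n(C2CCCC2)c2nc(N/N=C/c3ccc(F)cc3Br)ncc21` differs from compound 3 by one change: 2-bromo-4-fluorophenyl in place of 2,4-dimethoxyphenyl on a carbon with a double bond to nitrogen. Its 2-bromo-4-fluorophenyl group carries fluorine, as does the 3-chloro-4-fluorophenyl group of compound 1. The closest guide is therefore an at least 11-fold higher number from compound 1 to compound 3 (1.04 log units; beyond the scatter), which runs the opposite way. Also relevant is an 8.7-fold higher number from compound 1 to compound 2 (0.94 log units; beyond the scatter), whereas an at least 1.2-fold higher number from compound 2 to compound 3 (0.10 log units; that floor lies within the scatter) has a floor within the scatter. A large move toward lower numbers is expected, bringing compound 4 near compound 1.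

The expected change is an at least 7.1-fold lower number from compound 3 to compound 4 (0.85 log units; beyond the scatter).

Compound 4 is estimated at 14000 nM, with an expected range from 4000 nM to 50000 nM.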

Compound 4, half-maximal inhibitory concentration: 8390 nM
The estimate for compound 4 lay 1.7-fold (0.22 log units) above the measured number; low and high end bracket the measured number.
By their numbers in this assay, from the lowest: compounds 4 and 1 (each within the scatter of the next); then compound 2. At a limit, above all of these: compound 3.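

Putting 2-bromo-4-fluorophenyl in place of 2,4-dimethoxyphenyl gives an at least 11-fold lower number from compound 3 to compound 4 (1.07 log units; beyond the scatter), and that size is only a floor, as compound 3 has just a limit: the limit of > 100000 nM in this assay, at which 1 of the 4 values shown sits.

The same group also stands clear of furan-2-yl, with a 9.4-fold lower number from compound 2 to compound 4 (0.97 log units; beyond the scatter). Against 3-chloro-4-fluorophenyl it gives a 1.1-fold lower number from compound 1 to compound 4 (0.03 log units; within the scatter), so these two halogen-bearing phenyl groups cannot be told apart at this position.

From the compounds shown here alone, whether either halogen alone would suffice remains open, as does what a plain phenyl or a phenyl bearing an amine would do on this carbon.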